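A Second Methoxy on the Pendant Phenyl Ring

This account rests on a few compounds, and the source may have more. Where it says the series, first, only, none or still open, it means among the compounds named here.

In a functional assay on MKN-45 cells (Homo sapiens) for cytotoxicity, read by MTT assay, with a stated time of 72 h (on this read-out lower numbers stand for stronger inhibition and higher numbers for weaker inhibition), compound 1 `COc1cc2c(Oc3ccc(NC(=O)c4cc(-c5ccccc5)ccn4)cc3F)ccnc2cc1OCCCN1CCN(C)CC1` gives 150 nM.
Compound 2 `COc1cc2c(Oc3ccc(NC(=O)c4cc(-c5ccc(C(F)(F)F)cc5)ccn4)cc3F)ccnc2cc1OCCCN1CCN(C)CC1` gives 330 nM.
Compound 3 `COc1ccc(-c2ccnc(C(=O)Nc3ccc(Oc4ccnc5cc(OCCCN6CCN(C)CC6)c(OC)cc45)c(F)c3)c2)cc1` gives 250 nM.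

Compound 3 stands second highest of these three numbers; its nearest neighbour is compound 2, and the step of a 1.3-fold lower number from compound 2 to compound 3 (0.12 log units; within the scatter) lies within the scatter, as does a 1.7-fold higher number from compound 1 to compound 3 (0.22 log units; within the scatter). Compound 4 `COc1ccc(-c2ccnc(C(=O)Nc3ccc(Oc4ccnc5cc(OCCCN6CCN(C)CC6)c(OC)cc45)c(F)c3)c2)c(OC)c1` differs from compound 3 by methoxy in place of hydrogen on an aromatic carbon. For the measured compounds named here, two measured steps bear on this change: a 1.7-fold higher number from compound 1 to compound 3 (0.22 log units; within the scatter), the same kind of substitution, and a 2.2-fold higher number from compound 1 to compound 2 (0.34 log units; beyond the scatter). Neither of those steps was large. The expected step is therefore a 1.3-fold higher number from compound 3 to compound 4 (0.11 log units; within the scatter) in this assay, quite possibly none beyond the scatter, with a slight lean toward a higher number. Compound 4 is estimated at 320 nM, ranging from 150 nM to 700 nM.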

Compound 4, half-maximal inhibitory concentration: 330 nM
Compound 4: middle estimate off by 1.0-fold (0.01 log units), on the low side; the range from low to high includes it.
By their numbers in this assay, from the lowest: compounds 1, 3, 2 and 4 (each within the scatter of the next, the first and the last beyond it).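

In this assay, going from 4-methoxyphenyl to 2,4-dimethoxyphenyl gives a 1.3-fold higher number from compound 3 to compound 4 (0.12 log units; within the scatter), so a methoxy ortho to a large group brings no change that can be told from the scatter. Measured from the plain phenyl, however, the two methoxy groups together give a 2.2-fold higher number from compound 1 to compound 4 (0.34 log units; beyond the scatter), which passes the scatter, as the single methoxy in a 1.7-fold higher number from compound 1 to compound 3 (0.22 log units; within the scatter) did not. Against the trifluoromethyl compound, no change at the digits printed from compound 2 to compound 4 (within the scatter) leaves the two substituted rings indistinguishable.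

Going by these compounds, whether an amine or a carboxylic acid at this position would move the number further remains open. Nothing measured here offers an explanation for these numbers.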